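The source may hold more compounds than are shown below. What is called first, only, known or untested is meant among the compounds shown, and "the series" means these compounds.

Four compounds built on one shared core are compared here. Compound 1 `Cc1ccc(-c2nc(N)c3cc(-c4ccccc4)sc3n2)o1`, compound 2 `Cc1ccc(-c2nc(N)c3cc(Cc4ccccc4)sc3n2)o1` and compound 3 `Nc1nc(-c2ccccc2)nc2sc(-c3ccccc3)cc12` have been measured; compound 4 `Nc1nc(-c2ccccc2)nc2sc(Cc3ccccc3)cc12` has not.

The test is a functional assay on CHO-K1 cells for antagonist activity at adenosine receptor A1 (Homo sapiens), read by a beta-galactosidase reporter and cAMP accumulation, with stated times of 15 min and 6 h; a higher number here means a weaker inhibitor, a lower number a stronger inhibitor. In it compound 1 gives 520 nM, compound 2 gives 298 nM, and compound 3 gives 237 nM.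

Two single changes connect the measured compounds. The change benzyl in place of phenyl on an aromatic carbon gave a 1.7-fold lower number from compound 1 to compound 2 (0.24 log units; within the scatter). The change phenyl in place of 5-methylfuran-2-yl on an aromatic carbon gave a 2.2-fold lower number from compound 1 to compound 3 (0.34 log units; beyond the scatter).

Compound 4 differs from compound 3 by benzyl in place of phenyl on an aromatic carbon. For the measured compounds named here, this is the same change as the one from compound 1 to compound 2, made on the other core; the two cores differ by phenyl in place of 5-methylfuran-2-yl on an aromatic carbon, and the place of the change is described in the same words for both pairs.

Going by the values given here, the expectation for compound 4 therefore rests on the single earlier example: the step from compound 1 to compound 2, a 1.7-fold lower number from compound 1 to compound 2 (0.24 log units; within the scatter), which stayed within the scatter. Among the compounds with values here, a step of about the same size, a 1.6-fold lower number from compound 3 to compound 4 (0.20 log units; within the scatter), is expected from compound 3 to compound 4 in this assay, with wide uncertainty since only one example supports it. Compound 4 is estimated at 150 nM, likely between 65 nM and 350 nM.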

Compound 4, inhibition constant: 151 nM
Compound 4: the middle estimate sits 1.0-fold (0.00 log units) below what was measured; the range from low to high includes it.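

In this assay, benzyl in place of phenyl gave a 1.6-fold lower number from compound 3 to compound 4 (0.20 log units; within the scatter), much the same result as on the other core: the same change on two cores in this assay, a 1.7-fold lower number (0.24 log units; within the scatter) from compound 1 to compound 2 and a 1.6-fold lower number (0.20 log units; within the scatter) from compound 3 to compound 4, 1.1-fold (0.05 log units) apart, within the scatter of two such steps

Phenyl in place of 5-methylfuran-2-yl gave a 2.0-fold lower number from compound 2 to compound 4 (0.30 log units; within the scatter), and this change also carried across: the same change on two cores in this assay, a 2.2-fold lower number (0.34 log units; beyond the scatter) from compound 1 to compound 3 and a 2.0-fold lower number (0.30 log units; within the scatter) from compound 2 to compound 4, 1.1-fold (0.05 log units) apart, within the scatter of two such steps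

Across these four compounds, each change therefore had about the same size on both cores, but the two comparisons use the same four compounds and so amount to a single check, and the benzyl step stays within the scatter on both cores, so it cannot be told from no real change at all.

The compounds shown leave open whether the same agreement would hold on a core with a different group in place of phenyl or 5-methylfuran-2-yl. They also leave open how a longer chain such as 2-phenylethyl, or an amine or a carboxylic acid, would behave on the aromatic carbon next to the ring sulfur.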